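Working notes: swapping the last ring of compound 2

A few compounds are considered here, and "the series" means these few. Any claim that something is new, unique, unknown or untested is made for them only; others in the source may bear on it.

Measured in an ADME assay on L6 cells (Rattus norvegicus) for cytotoxicity; a higher number here means a weaker inhibitor, a lower number a stronger inhibitor:
- compound 1 `N=C(N)c1ccc2cc(-c3ccc(-c4ccc(C(=N)N)o4)o3)[nH]c2c1`: 16500 nM
- compound 2 `N=C(N)c1ccc2cc(-c3ccc(-c4ccc(C(=N)N)o4)s3)[nH]c2c1`: 17600 nM

Compound 2, at 17600 nM, stands level with compound 1 at 16500 nM, as the two values lie within the scatter of each other. Compound 3 `N=C(N)c1ccc2cc(-c3ccc(-c4ccc(C(=N)N)s4)s3)[nH]c2c1` is related to compound 2 by one change: a group of 8 heavy atoms (5 carbon, 2 nitrogen, 1 sulfur; one five-membered aromatic ring with 1 hetero atom) in place of a group of 8 heavy atoms (5 carbon, 2 nitrogen, 1 oxygen; one five-membered aromatic ring with 1 hetero atom), on an aromatic carbon. The change lies on an aromatic carbon of a five-membered aromatic ring with 1 sulfur, next to the ring sulfur. Among the compounds with values here, no measured pair shows this exact change, so the expectation rests only on the two close values in this assay. No step beyond the scatter is expected, in either direction. The estimated step of a 1.0-fold lower number from compound 2 to compound 3 (0.02 log units; within the scatter) is accordingly small. For compound 3 the expected value is 17000 nM, with an estimated range of 6500 nM to 45000 nM.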

Compound 3, half-maximal inhibitory concentration: 11600 nM
For compound 3 the middle estimate is 1.5-fold (0.17 log units) above the measured one, and the stated range covers the measured number.
By their numbers in this assay, from the lowest: compounds 3, 1 and 2 (each within the scatter of the next).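

In this assay, putting the group with 1 sulfur in place of the group with 1 oxygen gives a 1.5-fold lower number from compound 2 to compound 3 (0.18 log units; within the scatter). Within the data shown here, this is the first step read at this position, on an aromatic carbon of a five-membered aromatic ring with 1 sulfur, and it shows that the two groups are not told apart here: the exchange of ring oxygen for ring sulfur in this group is tolerated within the scatter. No measurement on hand bears on why the two groups read alike.

From the compounds shown here alone, whether a group of another kind at this place, such as a carboxylic acid or a primary amine, would give a step beyond the scatter stays open. Also open, going by these compounds, is whether the same exchange reads alike on a different core.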